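Lipophilicity notes: relocating a methyl group in the series

The compounds below may be only part of what the source reports. "The series", "measured", "known", "first", "only" and "open" are said of these compounds alone.

Measured in a physicochemical assay for lipophilicity, measured as octanol-water partition, at pH 7.4; on this read-out lower numbers stand for lower lipophilicity and higher numbers for higher lipophilicity:
- compound 1 `O=C(N[C@H]1CN(S(=O)(=O)c2ccccc2)C[C@@H]1C(=O)N1C[C@H]2CCNC[C@H]21)c1cc(-c2ccccc2Cl)on1`: 1.7
- compound 2 `O=C(N[C@H]1CN(S(=O)(=O)c2ccccc2)C[C@@H]1C(=O)NC[C@@H]1CCCN1)c1cc(-c2ccccc2Cl)on1`: 1.5
- compound 3 `CN(C(=O)[C@H]1CN(S(=O)(=O)c2ccccc2)C[C@@H]1NC(=O)c1cc(-c2ccccc2Cl)on1)[C@H]1CCCNC1`: 1.7

In this assay compound 3 gives 1.7, level at the digits shown with compound 1 at 1.7. The value of compound 2 at 1.5 lies within the scatter of both.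

Compound 4 `CN1CCC[C@H](NC(=O)[C@H]2CN(S(=O)(=O)c3ccccc3)C[C@@H]2NC(=O)c2cc(-c3ccccc3Cl)on2)C1` has the same atoms as compound 3, joined differently: a group of 8 heavy atoms (6 carbon, 2 nitrogen; one six-membered non-aromatic ring with 1 hetero atom) in place of a group of 8 heavy atoms (6 carbon, 2 nitrogen; one six-membered non-aromatic ring with 1 hetero atom), on a carbonyl carbon. The entering group is (1-methylpiperidin-3-yl)amino, on a carbonyl carbon whose other neighbours are: saturated ring carbon.

Within the data shown here, no measured pair makes this exact exchange. The closest evidence is the three exchanges at the same carbonyl carbon. These are a number 0.20 log units lower from compound 1 to compound 2 (within the scatter), no change at the digits printed from compound 1 to compound 3 (within the scatter) and a number 0.20 log units higher from compound 2 to compound 3 (within the scatter). All three stay within the scatter, although the groups exchanged differ in ring size and ring count. These three compounds are few, and they do not test this exchange directly, so the range is kept wider than the steps seen so far.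

No step beyond the scatter is expected in this assay. The estimated step is a number 0.20 log units higher from compound 3 to compound 4 (within the scatter). For compound 4 the estimated value is 1.9, with an expected range from 1.5 to 2.3.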

Compound 4, distribution coefficient: 3.1
Beside the measured number, compound 4's estimate is 1.20 log units below it; the whole stated range lies below it.
By their numbers in this assay, from the lowest: compounds 2, 1 and 3 (each within the scatter of the next); then compound 4.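

In this assay, among these compounds, this carbonyl carbon is not as tolerant of exchange as the earlier compounds suggested: (1-methylpiperidin-3-yl)amino, with the same atoms as the group it replaces and equal counts of hydrogen-bond donors and acceptors, gives a number 1.40 log units higher from compound 3 to compound 4 (beyond the scatter). The other two comparisons give the same picture, with 1-methylpiperidin-3-yl in place of (pyrrolidin-2-yl)methyl on an amide-type nitrogen giving a number 1.60 log units higher from compound 2 to compound 4 (beyond the scatter), and the exchange against the group of compound 1 giving a number 1.40 log units higher from compound 1 to compound 4 (beyond the scatter), so a rearrangement of the same atoms here can produce a large step, while the exchanges among compounds 1, 2 and 3 all stayed within the scatter. Nothing available explains the size of this step.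

Going by these compounds, it remains open whether the step follows from the methyl group on the piperidine ring alone or needs the rest of the entering group as well. Piperidin-3-ylamino with no methyl group, 1-ethylpiperidin-3-ylamino and (1-methylpyrrolidin-3-yl)amino at this carbonyl carbon would help to separate these possibilities, as would the opposite configuration at the stereocentre of the entering group.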